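Varying the group on the carbonyl carbon

The compounds below may be only part of what the source reports. "The series", "measured", "known", "first", "only" and "open" are said of these compounds alone.

Compound 2 `C[C@@H]1CN(c2ccc(-c3n[nH]c4cnc(N5[C@H](C)CN(C(=O)N(C)C)C[C@@H]5C)nc34)cn2)CCN1` gives 6.4 nM in an assay on Sf9 cells for inhibition of activin receptor type-1 (Homo sapiens), read by HTRF, with a stated time of 3 h, in the presence of a further agent that is not named here (on this read-out higher numbers stand for weaker inhibition and lower numbers for stronger inhibition), and stands with compound 1 `COCC(=O)N1C[C@@H](C)N(c2ncc3[nH]nc(-c4ccc(N5CCN[C@H](C)C5)nc4)c3n2)[C@@H](C)C1`, which gives 7.3 nM, the two numbers within the scatter of each other. Compound 3 `CCOC(=O)N1C[C@@H](C)N(c2ncc3[nH]nc(-c4ccc(N5CCN[C@H](C)C5)nc4)c3n2)[C@@H](C)C1` carries ethoxy in place of dimethylamino on a carbonyl carbon. Among the compounds with values here, the only step measured at this place, a 1.1-fold lower number from compound 1 to compound 2 (0.06 log units; within the scatter), lay within the scatter; no exchange of dimethylamino for ethoxy has been measured. On that basis compound 3 is expected to show no step beyond the scatter, a 1.1-fold higher number from compound 2 to compound 3 (0.04 log units; within the scatter). The estimate for compound 3 is 7 nM, with a range from 3 nM to 16 nM.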

Compound 3, half-maximal inhibitory concentration: 4.9 nM
The estimate for compound 3 lay 1.4-fold (0.15 log units) above the measured number; the measured number falls inside the stated range.
By their numbers in this assay, from the lowest: compounds 3, 2 and 1 (each within the scatter of the next).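

In this assay, the exchange of dimethylamino for ethoxy on a carbonyl carbon gives a 1.3-fold lower number from compound 2 to compound 3 (0.12 log units; within the scatter) and the exchange of methoxymethyl for ethoxy gives a 1.5-fold lower number from compound 1 to compound 3 (0.17 log units; within the scatter). All three groups now lie within the scatter of one another, and this holds even for the widest gap in the set. No evidence bears on why these exchanges leave the number within the scatter.

As far as these compounds go, whether a longer chain such as butoxy, a phenyl ring or a carboxylic acid on this carbonyl carbon would give a step beyond the scatter remains open.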